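A few compounds are considered here, and "the series" means these few. Any claim that something is new, unique, unknown or untested is made for them only; others in the source may bear on it.

Within the data shown here, compound 3 `CCC1C(=O)N(C)c2cnc(-n3ccc4cc(C(=O)NC(C)C)ccc43)nc2N1c1ccn(C)n1` gives 125 nM in an assay for inhibition of serine/threonine-protein kinase PLK2 (Homo sapiens), read by FRET and Z'-LYTE, with a stated time of 1 h (a higher number here means a weaker inhibitor, a lower number a stronger inhibitor), the lowest of the three numbers so far, though its gaps to compound 2 `CCC1C(=O)N(C)c2cnc(-n3ccc4cc(C(=O)NCC(C)C)ccc43)nc2N1c1ccn(C)n1`, which gives 159 nM, and to compound 1 `CCC1C(=O)N(C)c2cnc(-n3ccc4cc(C(=O)NC)ccc43)nc2N1c1ccn(C)n1`, which gives 218 nM, both lie within the scatter. Compound 4 `CCC1C(=O)N(C)c2cnc(-n3ccc4cc(C(=O)NC5CCCC5)ccc43)nc2N1c1ccn(C)n1` differs from compound 3 by cyclopentyl in place of isopropyl on an amide-type nitrogen. The steps bearing on this change are the earlier substitutions at the same amide-type nitrogen, a 1.7-fold lower number from compound 1 to compound 3 (0.24 log units; within the scatter) and a 1.3-fold lower number from compound 2 to compound 3 (0.10 log units; within the scatter), with a 1.4-fold lower number from compound 1 to compound 2 (0.14 log units; within the scatter) also small. None of them shifted the number beyond the scatter, so for compound 4 no step beyond the scatter is expected in this assay, a 1.1-fold lower number from compound 3 to compound 4 (0.04 log units; within the scatter). Compound 4 is therefore estimated at 115 nM, within a range of 55 nM to 250 nM.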

Compound 4, half-maximal inhibitory concentration: 90.9 nM
The estimate for compound 4 lay 1.3-fold (0.10 log units) above the measured number; low and high end bracket the measured number.
By their numbers in this assay, from the lowest: compounds 4, 3, 2 and 1 (each within the scatter of the next, the first and the last beyond it).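

Cyclopentyl on the amide-type nitrogen gives the only step beyond the scatter among these compounds, a modest one against methyl (a 2.4-fold lower number from compound 1 to compound 4 (0.38 log units; beyond the scatter)). Against the other two groups the step stays within the scatter (a 1.4-fold lower number from compound 3 to compound 4 (0.14 log units; within the scatter); a 1.7-fold lower number from compound 2 to compound 4 (0.24 log units; within the scatter)), so cyclopentyl cannot be ranked ahead of isopropyl or isobutyl. Nothing available here accounts for the step against methyl.

From the compounds shown here alone, whether cyclohexyl, a larger carbon ring, would extend the step against methyl remains open. So does the effect of an amine or a carboxylic acid on the amide-type nitrogen substituent.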